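The source may hold more compounds than are shown below. What is called first, only, known or untested is meant among the compounds shown, and "the series" means these compounds.

Measured in a functional assay on J774 cells (Mus musculus) for cytotoxicity, read by resazurin assay; on this read-out higher numbers stand for weaker inhibition and lower numbers for stronger inhibition:
Compound 1 `OCCCCCC(O)c1ccc(-c2ccccc2F)cc1`: 22000 nM
Compound 2 `Cc1ccc(-c2ccc(C(O)CCCCCO)cc2)cc1`: 22000 nM

Compound 2 stands level with compound 1 at the digits shown. Compound 3 `OCCCCCC(O)c1ccc(-c2ccc(O)cc2)cc1` differs from compound 2 by hydroxy in place of methyl on an aromatic carbon. Going by the values given here, only one measured step bears on this, no change at the digits printed from compound 1 to compound 2 (within the scatter), and it lay within the scatter. Among the compounds with values here, it exchanged 2-fluorophenyl for 4-methylphenyl, and no measured compound carries the hydroxy, so its guidance is limited. No step beyond the scatter is therefore expected in this assay. The estimated step is a 1.2-fold higher number from compound 2 to compound 3 (0.07 log units; within the scatter). For compound 3 the expected value is 26000 nM, within an estimated range of 12000 nM to 55000 nM.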

Compound 3, half-maximal inhibitory concentration: 15000 nM
The estimate for compound 3 lay 1.7-fold (0.24 log units) above the measured number, and the stated range covers the measured number.
By their numbers in this assay, from the lowest: compounds 3, 1 and 2 (each within the scatter of the next).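

Hydroxy brings a hydrogen-bond donor and acceptor to this place, para to a large group, where methyl has neither, yet this assay shows a 1.5-fold lower number from compound 2 to compound 3 (0.17 log units; within the scatter). Against the 2-fluorophenyl of compound 1, the 4-hydroxyphenyl gives a 1.5-fold lower number from compound 1 to compound 3 (0.17 log units; within the scatter), so all three compounds stay within the scatter of one another despite these exchanges. No evidence at hand accounts for this reading. Going by these compounds, whether an amine or a carboxylic acid at this place would move the number beyond the scatter remains open.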